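Side-chain swaps on a shared core: working notes

A few compounds are considered here, and "the series" means these few. Any claim that something is new, unique, unknown or untested is made for them only; others in the source may bear on it.

Measured so far:
compound 1 `CC1NC(NC[C@H]2CCCO2)=Nc2ccccc21`, 163 nM
compound 2 `CC1NC(NC2CCC2)=Nc2ccccc21`, 122 nM
compound 3 `CCCNC1=Nc2ccccc2C(C)N1`, 153 nM

In an assay on isolated protein for binding affinity to 5-hydroxytryptamine receptor 5A (Homo sapiens) (on this read-out higher numbers stand for weaker inhibition and lower numbers for stronger inhibition), compound 1 gives 163 nM, the highest of the three numbers, yet its gaps to compound 3 and to compound 2 both sit within the scatter, so no order among the three can be drawn. Compound 4 `CCCCNC1=Nc2ccccc2C(C)N1` is not yet measured. It differs from compound 1 by propyl in place of oxolan-2-yl on a saturated chain carbon bound to an amine nitrogen. The closest measured step is a 1.1-fold lower number from compound 1 to compound 3 (0.03 log units; within the scatter), which trades the same oxolan-2-yl for ethyl. The step of a 1.3-fold higher number from compound 2 to compound 3 (0.10 log units; within the scatter), a propyl chain in place of cyclobutyl, and the step of a 1.3-fold lower number from compound 1 to compound 2 (0.13 log units; within the scatter) are likewise flat. Within the data shown here, every comparison among the measured compounds lies inside the scatter, so oxolan-2-yl, ethyl, propyl and cyclobutyl look interchangeable on this read-out, with only three compounds behind that reading. For compound 4 the expected step is a 1.1-fold lower number from compound 1 to compound 4 (0.04 log units; within the scatter), nothing beyond the scatter. Compound 4 is expected to give 150 nM, within a range of 70 nM to 320 nM.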

Compound 4, inhibition constant: 189 nM
Compound 4: middle estimate off by 1.3-fold (0.10 log units), on the low side, and the stated range covers the measured number.
By their numbers in this assay, from the lowest: compounds 2, 3, 1 and 4 (each within the scatter of the next).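

Replacing (oxolan-2-yl)methyl with butyl on the amine nitrogen gives a 1.2-fold higher number from compound 1 to compound 4 (0.06 log units; within the scatter) in this assay even though the oxygen, the ring and the defined stereocentre all leave, so none of the three is needed to keep the number in this range. The flat picture now also reaches an open chain longer than propyl: the added methyl gives a 1.2-fold higher number from compound 3 to compound 4 (0.09 log units; within the scatter) and the widest gap in the set, a 1.5-fold higher number from compound 2 to compound 4 (0.19 log units; within the scatter) between the cyclobutyl and butyl compounds, also stays inside the scatter. No supporting data bear on why these side-chain swaps leave the number flat.

From the compounds shown here alone, whether any group on this amine nitrogen can move the number beyond the scatter stays open. An amine, a carboxylic acid or a phenyl group in the side chain would test this, as would a chain much longer than butyl.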